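A few compounds are considered here, and "the series" means these few. Any claim that something is new, unique, unknown or untested is made for them only; others in the source may bear on it.

Measured compounds:
- compound 1, `COc1cccc(CNC(=O)c2[nH]c3nc(-c4cn[nH]c4)ccc3c2CN2CCN(C)CC2)c1` — 39 nM
- compound 2, `COc1cccc(CNC(=O)c2cc3ccc(-c4cn[nH]c4)nc3n2CCCO)c1` — 88 nM
- compound 3, `CCN(Cc1cccc(OC)c1)C(=O)c1c[nH]c2nc(-c3cn[nH]c3)ccc12` — 76 nM

All three share a core and the same methoxybenzyl amide; they differ in what sits on the ring nitrogen and on the amide nitrogen. In an assay on isolated protein for inhibition of Rho-associated protein kinase 1 (Homo sapiens) (a higher number here means a weaker inhibitor, a lower number a stronger inhibitor), compound 2 gives 88 nM, the highest number of the three. Compound 3 gives 76 nM, which is within the scatter of compound 2, so no order between these two is claimed. Compound 1 gives 39 nM, a lower number beyond the scatter, so compound 1 is the stronger inhibitor against compound 2 on these numbers.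

Compound 4, `COc1cccc(CNC(=O)c2cc3ccc(-c4cn[nH]c4)nc3n2CC2CC2)c1`, is not yet measured. It differs from compound 2 in one place: cyclopropyl in place of 2-hydroxyethyl on a saturated chain carbon bound to an aromatic nitrogen. Going by the values given here, no measured pair in the set shows this change, so no size can be read from the data for it. Among the compounds with values here, the three compounds measured so far sit close to one another, which gives no ground to expect a large move in either direction. The step from compound 2 to compound 4 is expected to be a 1.0-fold higher number from compound 2 to compound 4 (0.01 log units; within the scatter), none beyond the scatter. Compound 4 is estimated at 90 nM, with a range from 40 nM to 200 nM.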

Compound 4, half-maximal inhibitory concentration: 280 nM
Estimate against measurement, compound 4: 3.1-fold (0.49 log units) below; measured number above the stated range.
By their numbers in this assay, from the lowest: compounds 1, 3 and 2 (each within the scatter of the next, the first and the last beyond it); then compound 4.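

Notes on this position: in this assay, cyclopropyl in place of 2-hydroxyethyl on a saturated chain carbon bound to an aromatic nitrogen gives a 3.2-fold higher number from compound 2 to compound 4 (0.50 log units; beyond the scatter), the first step in the series that can be read at a single place, and it shows that the number responds to this group. The change holds the count at 3 heavy atoms, yet the leaving group has 1 hydrogen-bond donor and 1 hydrogen-bond acceptor and no ring, while the entering group has no donor or acceptor and one three-membered ring of carbon, so these differences travel together in this single pair. Nothing on hand gives a reason for the rise in the number at this step.

Still open, going by these compounds, is whether the step follows the departure of the hydroxyl or the arrival of the cyclopropyl ring, a question on which a plain propyl chain and a 3-methoxypropyl chain at this place would bear. Equally open, on these data alone, is how an amine or a carboxylic acid at the end of the chain, or a longer chain, would read in this assay.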